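From 3,4-difluorophenyl to 3-methylphenyl on the sulfonyl sulfur

The source may hold more compounds than are shown below. What is called first, only, known or untested is meant among the compounds shown, and "the series" means these compounds.

Compound 1 `O=C(NCc1ccc(S(=O)(=O)c2cccc(F)c2)cc1)c1cc2cnccc2[nH]1` gives 11 nM
Compound 2 `O=C(NCc1ccc(S(=O)(=O)c2ccc(F)c(F)c2)cc1)c1cc2cnccc2[nH]1` gives 14 nM

Among the measured compounds shown here, in a functional assay on A2780 cells (Homo sapiens) for inhibition, read by sulforhodamine B assay, with a stated time of 72 h (a lower number here means a stronger inhibitor, a higher number a weaker inhibitor), compound 2, at 14 nM, lies within the scatter of compound 1, the only other compound measured so far. Compound 3 `Cc1cccc(S(=O)(=O)c2ccc(CNC(=O)c3cc4cnccc4[nH]3)cc2)c1` has not yet been measured. It shares the core of compound 2 and carries 3-methylphenyl in place of 3,4-difluorophenyl on a sulfonyl sulfur. For the measured compounds named here, only one measured step bears on this change, and only in part: a 1.3-fold higher number from compound 1 to compound 2 (0.10 log units; within the scatter), for fluoro in place of hydrogen on an aromatic carbon. Going by the values given here, no measured compound carries a methyl group on this ring, so the data give no direct reading for that group, and the range must stay wide. With a 1.3-fold higher number from compound 1 to compound 2 (0.10 log units; within the scatter) inside the scatter, no step beyond the scatter is expected in this assay, in either direction. The expected step is a 1.2-fold lower number from compound 2 to compound 3 (0.07 log units; within the scatter), which stays within that scatter. For compound 3 the estimated value is 12 nM, with an expected range from 5 nM to 30 nM overall.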

Compound 3, half-maximal inhibitory concentration: 4 nM
Compound 3: middle estimate off by 3.0-fold (0.48 log units), on the high side; the whole stated range lies above it.
By their numbers in this assay, from the lowest: compound 3; then compounds 1 and 2 (each within the scatter of the next).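

Among the earlier compounds, the only change on this ring was fluoro in place of hydrogen, and in this assay that change left compound 1 and compound 2 within the scatter of each other, so the ring had not yet shown any response to substitution. Among the compounds shown here, the methyl group gives the first steps beyond the scatter at this position: replacing 3,4-difluorophenyl on the sulfonyl sulfur gives a 3.5-fold lower number from compound 2 to compound 3 (0.54 log units; beyond the scatter), and methyl in place of fluoro on an aromatic carbon gives a 2.8-fold lower number from compound 1 to compound 3 (0.44 log units; beyond the scatter), so the ring's substituent can shift the number, though both steps are modest and rest on a single methyl compound. Nothing in the available evidence accounts for the lower number with methyl.

From the compounds shown here alone, with only these three compounds, it remains open whether the shift is specific to methyl or would also appear with a chloro, methoxy or ethyl group on the ring. Going by these compounds, it is equally open how the number would respond to an amine or a carboxylic acid there, or to a methyl group elsewhere on the ring.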